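Three close cytotoxicity numbers, then a larger change

A few compounds are considered here, and "the series" means these few. Any claim that something is new, unique, unknown or untested is made for them only; others in the source may bear on it.

Compound 1 `Cc1cc(C)c(Oc2cc(Nc3ccc(C#N)cc3)ncc2C(=O)NCc2cn(CC(N)=O)nn2)c(C)c1`: 24000 nM
Compound 2 `CCOC(=O)CCn1cc(CNC(=O)c2cnc(Nc3ccc(C#N)cc3)cc2Oc2c(C)cc(C)cc2C)nn1`: 21500 nM
Compound 3 `Cc1cc(C)c(Oc2cc(Nc3ccc(C#N)cc3)ncc2C(=O)NCc2cn(CCCO)nn2)c(C)c1`: 25200 nM

All three compounds share the same core and differ only in the group on a saturated chain carbon bound to an aromatic nitrogen. In an ADME assay on MT4 cells (Homo sapiens) for cytotoxicity, read by MTT assay, with a stated time of 5 days (on this read-out higher numbers stand for lower toxicity in this test and lower numbers for higher toxicity in this test), compound 3 gives 25200 nM, the highest of the three numbers, but each of its neighbours sits within the scatter: a 1.1-fold higher number from compound 1 to compound 3 (0.02 log units; within the scatter) and a 1.2-fold higher number from compound 2 to compound 3 (0.07 log units; within the scatter). The third step, a 1.1-fold lower number from compound 1 to compound 2 (0.05 log units; within the scatter), is equally small. So carbamoyl, (ethoxycarbonyl)methyl and 2-hydroxyethyl at this place gave numbers that cannot be told apart.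

Compound 4 `Cc1cc(C)c(Oc2cc(Nc3ccc(C#N)cc3)ncc2C(=O)NCc2cn(Cc3ccccc3Cl)nn2)c(C)c1` has not yet been measured. It differs from compound 3 by 2-chlorophenyl in place of 2-hydroxyethyl on a saturated chain carbon bound to an aromatic nitrogen. Within the data shown here, none of the measured steps exchanges a chain for an aromatic ring, so they only show that the three small chain groups made no difference; they do not cover this change. The step from compound 3 to compound 4 is therefore estimated as a 1.6-fold lower number from compound 3 to compound 4 (0.20 log units; within the scatter), with a wide range to allow for the unfamiliar group. Compound 4 is expected to give about 16000 nM in this assay, between 5000 nM and 40000 nM.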

Compound 4, half-maximal cytotoxic concentration: >= 188000 nM
Compound 4: only a limit was reported (the forecaster's own chance of this, stated with the estimate: 20%); middle value at least 11-fold (1.07 log units) from the limit.
By their numbers in this assay, from the lowest: compounds 2, 1 and 3 (each within the scatter of the next). At a limit, above all of these: compound 4.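

The value of compound 4 in this assay is a limit, not a number: the limit of >= 188000 nM in this assay, at which 1 of the 4 values shown sits.

The position is still not indifferent to what sits on it: the three small chain groups gave values within the scatter of each other, yet 2-chlorophenyl brings an at least 7.4-fold higher number from compound 3 to compound 4 (0.87 log units; beyond the scatter), an at least 8.7-fold higher number from compound 2 to compound 4 (0.94 log units; beyond the scatter) and an at least 7.8-fold higher number from compound 1 to compound 4 (0.89 log units; beyond the scatter). Higher numbers stand for lower toxicity in this test, so this change moves the result in the less toxic direction, by an amount the limit leaves unknown.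

With a single aromatic group shown, it stays open whether the ring or its chlorine goes with this shift. On these data alone, whether a plain phenyl without the chlorine, or an amine on the chain, gives the same shift is also open.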